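The source may report more compounds than this note shows. Statements on the series, on what has been measured and on what is new or still open speak of the compounds shown alone.

Compound 1 `c1ccc(COc2cccc(-c3cn(C4CN5CCC4CC5)nn3)c2)cc1` and compound 2 `Fc1ccc(COc2cccc(-c3cn([C@H]4CN5CCC4CC5)nn3)c2)cc1` share one scaffold. In an assay on HEK293 cells for displacement of a labelled ligand from Neuronal acetylcholine receptor; alpha4/beta2 (Homo sapiens), read by scintillation counting, with a stated time of 120 min (a higher number here means a weaker inhibitor, a lower number a stronger inhibitor), compound 1 gives 668 nM, while compound 2 gives 6390 nM, the higher of the two numbers and the weaker binder, with the gap to compound 1 lying beyond the scatter. Compound 3 `Fc1ccc(COc2cccc(-c3cn(C4CN5CCC4CC5)nn3)c2)cc1` differs from compound 2 only in how one stereocentre is drawn: the two compounds have the same atoms and bonds; at least one stereo element is drawn with a configuration in one of them and without one in the other: 1 of 3 stereo elements differ; a stereocentre at a saturated ring carbon is drawn R in compound 2 and without a configuration in compound 3. Compound 3 is therefore expected to contain the other arrangement as well, so a step down from compound 2 of roughly a 4.9-fold lower number from compound 2 to compound 3 (0.69 log units; beyond the scatter) is expected in this assay. Compound 3 is estimated at 1300 nM, within 400 nM to 4000 nM.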

Compound 3, inhibition constant: 1010 nM
Estimate against measurement, compound 3: 1.3-fold (0.11 log units) above; the measured number falls inside the stated range.
By their numbers in this assay, from the lowest: compounds 1 and 3 (each within the scatter of the next); then compound 2.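

Compound 1 and compound 2 differ in two places at once, and compound 3 separates those two changes. Leaving the saturated ring carbon without a drawn configuration gives a 6.3-fold lower number from compound 2 to compound 3 (0.80 log units; beyond the scatter), while fluoro in place of hydrogen gives a 1.5-fold higher number from compound 1 to compound 3 (0.18 log units; within the scatter), so that swap shows no readable difference. In this assay the first of these steps can be tied to one place alone: the fact that one of compounds 2 and 3 is drawn with a defined configuration and the other without, at the place where they differ

As far as these compounds go, the share of each arrangement in compound 3 remains unknown, as does the value of the opposite arrangement on its own. From the compounds shown here alone, whether a chloro or methoxy group in place of the fluoro would read the same also stays open.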